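A few compounds are considered here, and "the series" means these few. Any claim that something is new, unique, unknown or untested is made for them only; others in the source may bear on it.

Measured so far in an ADME assay on Caco-2 cells (Homo sapiens) for permeability; on this read-out lower numbers stand for lower permeability and higher numbers for higher permeability:
Compound 1 `Cc1ccc(NC(=O)CCc2nnc(CCCC(C)C)n2C2CC2)c(C)c1`: 36 10^-6 cm/s
Compound 2 `Cc1ccc(NC(=O)CC(CCN)c2nnc(CCCC(C)C)n2C2CC2)c(C)c1`: 0.2 10^-6 cm/s
Compound 3 `Cc1ccc(NC(=O)CC(CCC(=O)O)c2nnc(CCCC(C)C)n2C2CC2)c(C)c1`: 0.2 10^-6 cm/s

Compound 2 stands level with compound 3, and together they hold the lowest of the three numbers, far under compound 1. Compound 4 `Cc1ccc(NC(=O)CC(CCC(N)=O)c2nnc(CCCC(C)C)n2C2CC2)c(C)c1` differs from compound 2 by a single change, carbamoyl in place of amino on a saturated chain carbon, three bonds along the chain from an aromatic carbon. Among the compounds with values here, three measured steps bear on this. Adding a chain to compound 1 gave large drops, a 180-fold lower number from compound 1 to compound 2 (2.26 log units; beyond the scatter) with 2-aminoethyl and a 180-fold lower number from compound 1 to compound 3 (2.26 log units; beyond the scatter) with 2-carboxyethyl. Exchanging the end group of that chain gave no change at the digits printed from compound 2 to compound 3 (within the scatter). Compound 4 keeps the chain and exchanges only its end group, so a step of the small kind is expected in this assay, not a large one. No carbamoyl-ended chain has been measured, so a modest rise remains possible. The estimated step is a 3.0-fold higher number from compound 2 to compound 4 (0.48 log units; beyond the scatter). For compound 4 the expected value is 0.6 10^-6 cm/s, with an estimated range of 0.2 10^-6 cm/s to 3 10^-6 cm/s.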

Compound 4, apparent permeability: 0.8 10^-6 cm/s
Beside the measured number, compound 4's estimate is 1.3-fold (0.12 log units) below it; measured number inside the range.
By their numbers in this assay, from the lowest: compounds 2 and 3 (each within the scatter of the next); then compound 4; then compound 1.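

In this assay the end group of the chain on this saturated chain carbon proved able to move the number, although amino and carboxy had stood level. There is a 4.0-fold higher number from compound 2 to compound 4 (0.60 log units; beyond the scatter) when carbamoyl replaces amino, and a 4.0-fold higher number from compound 3 to compound 4 (0.60 log units; beyond the scatter) when amino replaces hydroxy on the carbonyl carbon. Even so, adding 2-carbamoylethyl to the unbranched compound still gives a 45-fold lower number from compound 1 to compound 4 (1.65 log units; beyond the scatter) as a large step, so only part of the gap is closed. No measurement given here accounts for the carbamoyl end standing apart from the other two.

Going by these compounds, whether a hydroxy group or a methyl ester at the chain end would behave like compound 4 stays open. So does whether a shorter chain such as carbamoylmethyl, or a longer chain with the same end group, would come closer to compound 1.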